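From 4-nitrophenyl to 2,4-difluorophenyl on a carbonyl carbon

The source may report more compounds than this note shows. Statements on the series, on what has been measured and on what is new or still open speak of the compounds shown alone.

compound 1 `Cc1ccc(N(C(=O)c2ccccc2[N+](=O)[O-])C(=S)OCCN2C(=O)c3ccccc3C2=O)cc1` gives 100000 nM
compound 2 `Cc1ccc(N(C(=O)c2cccc(C)c2)C(=S)OCCN2C(=O)c3ccccc3C2=O)cc1` gives > 100000 nM (a limit)
compound 3 `Cc1ccc(N(C(=O)c2ccc([N+](=O)[O-])cc2)C(=S)OCCN2C(=O)c3ccccc3C2=O)cc1` gives 58000 nM

In an ADME assay on MT4 cells (Homo sapiens) for cytotoxicity, read by MTT assay (on this read-out lower numbers stand for higher toxicity in this test and higher numbers for lower toxicity in this test), compound 3 gives 58000 nM as its value, which lies within the scatter of compound 1 at 100000 nM on this scale. Compound 2 gives only a limit (> 100000 nM). One caution applies to this small set (the limit of > 100000 nM in this assay, at which 1 of the 3 values shown sits).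

The next compound is compound 4 (`Cc1ccc(N(C(=O)c2ccc(F)cc2F)C(=S)OCCN2C(=O)c3ccccc3C2=O)cc1`), which carries 2,4-difluorophenyl in place of 4-nitrophenyl on a carbonyl carbon. Three measured steps change the group at this same place. Going by the values given here, the only one with a number at both ends is small (a 1.7-fold lower number from compound 1 to compound 3 (0.24 log units; within the scatter)). The two that involve compound 2 leave their size open (an at least 1.7-fold lower number from compound 2 to compound 3 (0.23 log units; that floor lies within the scatter) and a number no lower from compound 1 to compound 2 (the limit leaves the size open)). So far, then, no change at this place has a readable size beyond the scatter.

Compound 4 is therefore expected to stay in the same high range of numbers, and it may also return only a limit. The expected change is small (a 1.3-fold higher number from compound 3 to compound 4 (0.11 log units; within the scatter)) and no larger than the scatter. For compound 4 the estimate is 75000 nM as the middle value, with an expected range from 35000 nM to 100000 nM in this read-out.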

Compound 4, half-maximal cytotoxic concentration: 20000 nM
The estimate for compound 4 lay 3.8-fold (0.57 log units) above the measured number; measured number outside the range, below it.
By their numbers in this assay, from the lowest: compound 4; then compounds 3 and 1 (each within the scatter of the next).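

Going by these compounds alone, this is the first change at this place, on a carbonyl carbon whose other neighbour is an amide-type nitrogen, with a readable size beyond the scatter in this assay: there is a 2.9-fold lower number from compound 3 to compound 4 (0.46 log units; beyond the scatter), and there is a 5.0-fold lower number from compound 1 to compound 4 (0.70 log units; beyond the scatter). The group on this carbonyl carbon can therefore move the number, which the earlier swaps among 2-nitrophenyl, 3-methylphenyl and 4-nitrophenyl did not show, and here 2,4-difluorophenyl gives the lowest number of the set, meaning the highest toxicity in this test. Compound 2 has only a limit as its value, so its step gives a floor and not a full size, an at least 5.0-fold lower number from compound 2 to compound 4 (0.69 log units; beyond the scatter): the limit of > 100000 nM in this assay, at which 1 of the 4 values shown sits.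

The compounds shown cannot separate the two parts of this swap, the arrival of the two fluorines and the departure of the nitro group, since both happen in the same step. On these data alone, it also stays open whether a phenyl ring with a single fluorine, or a phenyl ring bearing an amine or a carboxylic acid, would give a number as low as that of compound 4.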